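The compounds below may be only part of what the source reports. "The series", "measured", "known", "first", "only" and "open" are said of these compounds alone.

- compound 1 `COc1ccccc1C(=O)Nc1ccc(N2CCN(c3ccccn3)CC2)cc1`: > 10000 nM (a limit)
- compound 2 `COc1ccccc1C(=O)Nc1ccc(N2CCN(c3cccc(C)c3C)CC2)cc1C(=O)O`: 22900 nM

Among the measured compounds shown here, in a toxicity assay on L3.6pl cells (Homo sapiens) for inhibition, read by ATP content, with a stated time of 72 h (on this read-out higher numbers stand for weaker inhibition and lower numbers for stronger inhibition), compound 2 gives 22900 nM, the only actual number so far. Compound 1 has only a limit, > 10000 nM.

Compound 3 `COc1ccccc1C(=O)Nc1ccc(N2CCN(CCCc3ccccc3)CC2)cc1C(=O)O` carries 3-phenylpropyl in place of 2,3-dimethylphenyl on an amine nitrogen in a ring. For the measured compounds named here, no measured pair shows what such a swap does. With compound 2 at 22900 nM as the only anchor, no shift beyond the scatter in this assay is expected, in either direction. The expected step is small: a 1.1-fold lower number from compound 2 to compound 3 (0.06 log units; within the scatter). For compound 3, the estimate is 20000 nM, with an expected range of 8000 nM to 50000 nM.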

Compound 3, half-maximal inhibitory concentration: > 10000 nM
Compound 3: only a limit was reported; the forecaster's own chance of this, stated with the estimate: 35%; the middle value is on the limit's open side.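

No step can be read from compound 2 to compound 3, because compound 3 has only a limit and not a number: the limit of > 10000 nM in this assay, at which 2 of the 3 values shown sit. The compounds shown leave open whether 3-phenylpropyl in place of 2,3-dimethylphenyl shifts the result in this assay in either direction.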